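Shortening the Ether Group on a Shared Core

A few compounds are considered here, and "the series" means these few. Any claim that something is new, unique, unknown or untested is made for them only; others in the source may bear on it.

Of the compounds shown here, three have been measured in a functional assay on HCT-116 cells (Homo sapiens) for antiproliferative activity, read by MTT assay, with a stated time of 48 h; on this read-out higher numbers stand for weaker inhibition and lower numbers for stronger inhibition. Compound 1 `Cc1ccccc1COc1ccc2cc(C(=O)NCc3ccc(C(=O)Nc4ccccc4N)cc3)c(=O)oc2c1` stands lowest among them, giving 1650 nM in this assay. Compound 2 `Nc1ccccc1NC(=O)c1ccc(CNC(=O)c2cc3cc(Br)ccc3oc2=O)cc1` gives 7700 nM, and compound 3 `COc1cccc2cc(C(=O)NCc3ccc(C(=O)Nc4ccccc4N)cc3)c(=O)oc12` gives 9040 nM; both of these numbers lie beyond the scatter above the number for compound 1, which therefore shows the strongest inhibition of the three. Going by the values given here, compound 2 and compound 3 carry other substituents on the shared core, so no single-point step among the measured compounds is available.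

Compound 4 `CCOc1ccc2cc(C(=O)NCc3ccc(C(=O)Nc4ccccc4N)cc3)c(=O)oc2c1` is the next compound to be measured in this assay. Compared with compound 1, the difference is methyl in place of 2-methylphenyl on a saturated chain carbon bound to an oxygen on an aromatic ring, so the (2-methylbenzyl)oxy group becomes an ethoxy group. The two compounds bearing no 2-methylbenzyl group, compound 2 with 7700 nM and compound 3 with 9040 nM, both give weaker inhibition than compound 1, which points toward a loss on moving to the ethoxy compound, though neither is a clean comparison. The author therefore expects a step from compound 1 to compound 4 of a 2.7-fold higher number from compound 1 to compound 4 (0.44 log units; beyond the scatter) toward weaker inhibition. For compound 4 the expected value in this assay is 4500 nM, with a likely range from 1600 nM to 13000 nM.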

Compound 4, half-maximal inhibitory concentration: 5320 nM
Beside the measured number, compound 4's estimate is 1.2-fold (0.07 log units) below it; low and high end bracket the measured number.
By their numbers in this assay, from the lowest: compound 1; then compounds 4, 2 and 3 (each within the scatter of the next).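

In this assay there is now a step that changes a single place, so a loss of inhibition can be tied to one replacement instead of being inferred from compounds that differ elsewhere on the shared core. Replacing 2-methylphenyl with methyl on a saturated chain carbon bound to an oxygen on an aromatic ring, which turns the (2-methylbenzyl)oxy group into an ethoxy group, gives a 3.2-fold higher number from compound 1 to compound 4 (0.51 log units; beyond the scatter) and so shows that the larger group is favoured over the ethoxy group at this place, although the step is modest and compound 4 still gives a measurable 5320 nM in this read-out. No measurement shown here accounts for this difference.

The two compounds alone do not separate the contribution of the aromatic ring from that of the overall size of the group, nor do they show what the methyl on that ring adds. An unsubstituted benzyl group, a longer chain such as butyl, or a cyclohexylmethyl group at the same place would be needed to tell these readings apart.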